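The source may report more compounds than this note shows. Statements on the series, on what has been measured and on what is new or still open speak of the compounds shown alone.

Measured so far in an ADME assay on BHK-21 cells (Mesocricetus auratus) for cytotoxicity, read by MTT assay, with a stated time of 72 h; on this read-out higher numbers stand for lower toxicity in this test and lower numbers for higher toxicity in this test

Compound 1 (`Cc1ccccc1C1CC(c2ccc(OCc3ccccc3)cc2)=NN1c1ccc(S(N)(=O)=O)cc1`) with 20000 nM
Compound 2 (`NS(=O)(=O)c1ccc(N2N=C(c3ccc(OCc4ccccc4)cc3)CC2c2ccccc2Cl)cc1`) with 12000 nM

Within the data shown here, on this read-out compound 2 at 12000 nM lies within the scatter of compound 1, the only other compound measured. Compound 3 (`NS(=O)(=O)c1ccc(N2N=C(c3ccc(OCc4ccccc4)cc3)CC2c2ccc(Cl)cc2)cc1`) differs from compound 2 by 4-chlorophenyl in place of 2-chlorophenyl on a saturated ring carbon with 4-chlorophenyl in place of 2-chlorophenyl on a saturated ring carbon. Among the measured compounds shown here, the only measured step, chloro in place of methyl, is a 1.7-fold lower number from compound 1 to compound 2 (0.22 log units; within the scatter) and stays within the scatter. For the measured compounds named here, no measured step moves the chlorine, so the evidence is indirect. For compound 3 no shift beyond the scatter is expected in this assay and the estimated change is a 1.2-fold higher number from compound 2 to compound 3 (0.07 log units; within the scatter) at most modest. Compound 3 is expected at 14000 nM with an estimated range of 6000 nM to 30000 nM in this test.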

Compound 3, half-maximal cytotoxic concentration: 15000 nM
Compound 3: middle estimate off by 1.1-fold (0.03 log units), on the low side; low and high end bracket the measured number.
By their numbers in this assay, from the lowest: compounds 2, 3 and 1 (each within the scatter of the next).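

In this assay 4-chlorophenyl in place of 2-chlorophenyl on the saturated ring carbon gives a 1.3-fold higher number from compound 2 to compound 3 (0.10 log units; within the scatter) and 4-chlorophenyl in place of 2-methylphenyl gives a 1.3-fold lower number from compound 1 to compound 3 (0.12 log units; within the scatter), so neither step leaves the scatter. Where the chlorine sits on this phenyl ring therefore makes no readable difference in this test, which the earlier swap of chloro for methyl could not show. Nothing available here bears on the reason for this result. Still open, going by these compounds, is whether an amine, a carboxylic acid or a longer chain on this phenyl ring would give a step beyond the scatter.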